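The source may report more compounds than this note shows. Statements on the series, on what has been measured and on what is new or still open speak of the compounds shown alone.

Measured in a physicochemical assay for lipophilicity; on this read-out lower numbers stand for lower lipophilicity and higher numbers for higher lipophilicity:
Compound 1 `C=C(c1ccc2ccccc2c1)C1CCC2(CC1)COC(Nc1ccc(F)cc1)OO2`: 5.75
Compound 2 `C=C(c1ccc2ccccc2c1)C1CCC2(CC1)COC(Nc1ccc(Cl)cc1)OO2`: 6.15
Compound 3 `C=C(c1ccc2ccccc2c1)C1CCC2(CC1)COC(Nc1ccc(OC)cc1)OO2`: 5.46

Compound 3, at 5.46, shares the low end of this small set with compound 1. The record shows a number 0.29 log units lower from compound 1 to compound 3 (within the scatter), and it also shows a number 0.69 log units lower from compound 2 to compound 3 (beyond the scatter). The next compound keeps the shared core. In compound 4 `C=C(c1ccc2ccccc2c1)C1CCC2(CC1)COC(Nc1ccccc1-c1ccccc1)OO2`, 2-phenylphenyl stands in place of 4-methoxyphenyl on an amine nitrogen (2-phenylphenyl in place of 4-methoxyphenyl on an amine nitrogen).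

The measured steps offer only partial guidance. Each swaps one group for another on an aromatic carbon, and none replaces the whole aryl group on the amine nitrogen. They are a number 0.40 log units higher from compound 1 to compound 2 (beyond the scatter), together with the two steps above. The largest, a number 0.69 log units lower from compound 2 to compound 3 (beyond the scatter), sets the scale of what a single swap has done so far. The present change is structurally larger, and the entering group holds more carbon and no oxygen. A step towards a higher number is therefore expected, larger than any measured so far in this assay. The expected step is a number 1.44 log units higher from compound 3 to compound 4 (beyond the scatter). Compound 4 is estimated at 6.9, with an expected range from 6.3 to 7.5.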

Compound 4, partition coefficient: 7.26
Estimate against measurement, compound 4: 0.36 log units below, and the stated range covers the measured number.
By their numbers in this assay, from the lowest: compounds 3 and 1 (each within the scatter of the next); then compound 2; then compound 4.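

Replacing the whole aryl group on the amine nitrogen moved the number in this assay much further than any swap on an aromatic carbon had, with a number 1.80 log units higher from compound 3 to compound 4 (beyond the scatter) and a number 1.11 log units higher from compound 2 to compound 4 (beyond the scatter) and also a number 1.51 log units higher from compound 1 to compound 4 (beyond the scatter), while the largest earlier step was a number 0.69 log units lower from compound 2 to compound 3 (beyond the scatter). Compound 4 therefore stands clear of all three single-ring compounds, so the rise at this position holds whichever of 4-methoxyphenyl, 4-chlorophenyl or 4-fluorophenyl it is compared with, and the read-out spans a wider range at this position than the earlier swaps alone had shown. Nothing available explains why the number rises this far.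

The compounds shown leave open how much of the step belongs to the added phenyl ring and how much to where that ring sits, a question that plain phenyl or 4-phenylphenyl on the same amine nitrogen would help to separate. Going by these compounds, it also remains open whether a pyridyl ring or a carboxylic acid in the entering group would bring the number back down while keeping the second ring.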